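A few compounds are considered here, and "the series" means these few. Any claim that something is new, unique, unknown or untested is made for them only; others in the source may bear on it.

Compound 1 `CC(=O)Nc1nc2ccc(-c3cnc(Cl)c(NS(=O)(=O)c4ccc(F)cc4)c3)cn2n1`: 19800 nM
Compound 2 `COc1ncc(-c2ccc3nc(NC(C)=O)nn3c2)cc1NS(=O)(=O)c1ccc(F)cc1`: 840 nM
Compound 3 `COc1ncc(-c2ccc3nc(NC(=O)C4CC4)nn3c2)cc1NS(=O)(=O)c1ccc(F)cc1`: 2590 nM

The three measured compounds were tested in a functional assay on MCF7 cells (Homo sapiens) for antiproliferative activity, read by MTT assay, with a stated time of 48 h; a lower number here means a stronger inhibitor, a higher number a weaker inhibitor. Compound 3 stands second highest of the three numbers there, with compound 2 its nearest neighbour; the step of a 3.1-fold higher number from compound 2 to compound 3 (0.49 log units; beyond the scatter) came with cyclopropyl in place of methyl on the carbonyl carbon, and compound 1 lies further off, at a higher number than compound 3.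

Compound 4 `O=C(Nc1nc2ccc(-c3cnc(Cl)c(NS(=O)(=O)c4ccc(F)cc4)c3)cn2n1)C1CC1` is the compound not yet measured. It differs from compound 3 in one place: chloro in place of methoxy on an aromatic carbon, on an aromatic carbon of a six-membered aromatic ring with one nitrogen, next to the ring nitrogen, ortho to the ((4-fluorophenyl)sulfonyl)amino group and para to a large group.

Among the measured compounds shown here, one measured step bears on this change directly, in the reverse direction: a 24-fold lower number from compound 1 to compound 2 (1.37 log units; beyond the scatter), where methoxy replaced chloro at the same place. Reversing that step on compound 3 points to a large rise in the number for compound 4 in this assay. The same conclusion follows from compound 1, since compound 4 carries the cyclopropyl amide of compound 3 on the chloro scaffold of compound 1, and that amide change cost compound 3 the step of a 3.1-fold higher number from compound 2 to compound 3 (0.49 log units; beyond the scatter).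

Compound 4 is therefore expected to be a markedly weaker inhibitor than compound 3, the estimated step being a 19-fold higher number from compound 3 to compound 4 (1.29 log units; beyond the scatter). The estimate for compound 4 is 50000 nM, with a range from 15000 nM to 150000 nM.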

Compound 4, half-maximal inhibitory concentration: > 60000 nM
Compound 4: a limit, no number; the forecaster's own chance of this, stated with the estimate: 30%; at least 1.2-fold (0.07 log units) between middle value and limit.
By their numbers in this assay, from the lowest: compound 2; then compound 3; then compound 1. At a limit, above all of these: compound 4.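

The value of compound 4 in this assay is a limit of the assay and not a number: > 60000 nM. Even so, an at least 23-fold higher number from compound 3 to compound 4 (1.36 log units; beyond the scatter) shows that chloro in place of methoxy, on the aromatic carbon next to the ring nitrogen, carries a large penalty with the cyclopropyl amide as well as with the methyl amide, so the earlier finding is not confined to one core: the same change on two cores in this assay, a 24-fold lower number (1.37 log units; beyond the scatter) from compound 1 to compound 2 and an at least 23-fold lower number (1.36 log units; beyond the scatter) from compound 4 to compound 3; the limit leaves it open whether they differ The cyclopropyl change also runs in the same direction on the chloro core as on the methoxy core, with an at least 3.0-fold higher number from compound 1 to compound 4 (0.48 log units; beyond the scatter): the same change on two cores in this assay, a 3.1-fold higher number (0.49 log units; beyond the scatter) from compound 2 to compound 3 and an at least 3.0-fold higher number (0.48 log units; beyond the scatter) from compound 1 to compound 4; the limit leaves it open whether they differ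

The limit leaves open the true size of both new steps, and so whether the effects of the chloro and cyclopropyl changes simply add up or go further together on this core. The compounds shown also leave open how an ethoxy group or an amine at this position would compare with methoxy, and whether the effect of the methoxy group is specific to it.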